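The source may hold more compounds than are shown below. What is called first, only, known or untested is meant among the compounds shown, and "the series" means these compounds.

- compound 1 `COC1=C(C)C(=O)/C(=C(O)/C=C/c2ccc(OC)cc2)C(=O)C1(C)C`: 2.5 ug/mL
- compound 2 `COC1=C(C)C(=O)/C(=C(O)/C=C/c2ccc(O)cc2)C(=O)C1(C)C`: 3.8 ug/mL
- compound 3 `COC1=C(C)C(=O)/C(=C(O)/C=C/c2ccc(F)cc2)C(=O)C1(C)C`: 2 ug/mL

These three compounds share a core and differ only in the group on the aromatic ring. They were tested in a functional assay on HUVEC cells (Homo sapiens) for cytotoxicity; on this read-out lower numbers stand for an effect already at smaller amounts and higher numbers for an effect only at larger amounts of compound. In this assay, compound 3 gives 2 ug/mL, but this value does not set it apart from the other two. Its steps from them are a 1.3-fold lower number from compound 1 to compound 3 (0.10 log units; within the scatter) and a 1.9-fold lower number from compound 2 to compound 3 (0.28 log units; within the scatter), so all three compounds sit together on the numbers available.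

The next compound, compound 4 `COC1=C(C)C(=O)/C(=C(O)/C=C/c2ccccc2C)C(=O)C1(C)C`, changes that same aromatic part of the molecule. (2-methylphenyl in place of 4-fluorophenyl on a double-bonded chain carbon bound to a double-bonded chain carbon). Among the compounds with values here, no measured compound carries a 2-methylphenyl group, so the data offer no direct precedent for this swap.

The closest guide is what the other group swaps did. The measured steps are a 1.5-fold higher number from compound 1 to compound 2 (0.18 log units; within the scatter), together with the two above. Within the data shown here, each is small, so the three swaps give no reason to expect a large move, though this is a thin basis of only three compounds. The expected result is a 1.3-fold higher number from compound 3 to compound 4 (0.10 log units; within the scatter), which would be no change beyond the scatter. For compound 4 the estimated value is 2.5 ug/mL, with an expected range from 1.2 ug/mL to 5.5 ug/mL.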

Compound 4, concentration for half-maximal effect: 2.3 ug/mL
Estimate against measurement, compound 4: 1.1-fold (0.04 log units) above, within the range that was stated.
By their numbers in this assay, from the lowest: compounds 3, 4, 1 and 2 (each within the scatter of the next).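

In this assay, putting 2-methylphenyl in place of 4-fluorophenyl gives a 1.2-fold higher number from compound 3 to compound 4 (0.06 log units; within the scatter) and the swaps from the other two groups read the same way, with a 1.7-fold lower number from compound 2 to compound 4 (0.22 log units; within the scatter) for 4-hydroxyphenyl and a 1.1-fold lower number from compound 1 to compound 4 (0.04 log units; within the scatter) for 4-methoxyphenyl. Within the data shown here, the earlier compounds all carried a phenyl ring with a group named at its 4 position, so they showed only that swapping this one group made no difference beyond the scatter; compound 4 extends that finding to a ring whose methyl group is named at the 2 position, and all four compounds now sit together. Nothing available here explains why the numbers stay so close.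

As far as these compounds go, all four compounds carry a six-membered aromatic ring of carbon only at this place, so it remains open whether the picture would hold with an amine or a carboxylic acid on that ring, a longer chain in place of the methyl, or a ring containing nitrogen. The shared core is also identical throughout, so these compounds say nothing about how changes elsewhere in the molecule would affect the read-out.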